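This account rests on a few compounds, and the source may have more. Where it says the series, first, only, none or still open, it means among the compounds named here.

For the measured compounds named here, compound 2 `CC(C)C(=O)NC[C@@H]1C[C@H]1c1cccc2c1OC(C(C)C)N2` gives 1.3 nM in an assay on NIH3T3 cells with melatonin receptor type 1A (Homo sapiens) as the target (a lower number here means a stronger inhibitor, a higher number a weaker inhibitor), the lowest of the two numbers so far; compound 1 `CCC(=O)NC[C@@H]1C[C@H]1c1cccc2c1OC(C(C)C)N2` gives 4.9 nM in this assay, and a 3.8-fold lower number from compound 1 to compound 2 (0.58 log units; beyond the scatter). Compound 3 `CNC(=O)NC[C@@H]1C[C@H]1c1cccc2c1OC(C(C)C)N2` differs from compound 2 by methylamino in place of isopropyl on a carbonyl carbon, on the carbonyl carbon whose other neighbour is the amide-type nitrogen. Going by the values given here, no measured step touches that carbonyl substituent; the single step so far alters the saturated chain beyond it and gives no direction here. A modest loss is expected, though a number within the scatter cannot be excluded. Compound 3 is expected at 5 nM, between 1 nM and 25 nM. The expected step is a 3.8-fold higher number from compound 2 to compound 3 (0.59 log units; beyond the scatter).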

Compound 3, inhibition constant: 11.8 nM
Compound 3: middle estimate off by 2.4-fold (0.37 log units), on the low side, within the range that was stated.
By their numbers in this assay, from the lowest: compound 2; then compound 1; then compound 3.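

On the carbonyl carbon, methylamino in place of isopropyl gives a 9.1-fold higher number from compound 2 to compound 3 (0.96 log units; beyond the scatter), and methylamino in place of ethyl gives a 2.4-fold higher number from compound 1 to compound 3 (0.38 log units; beyond the scatter), so the nature of this substituent matters in both comparisons. Of the three groups shown here, isopropyl on compound 2 retains the lowest number, and methylamino on compound 3 has the highest. No evidence is available to explain the rise with methylamino. Whether the nitrogen itself accounts for the change remains open; dimethylamino, cyclopropyl or tert-butyl on this carbonyl carbon would address that.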